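A few compounds are considered here, and "the series" means these few. Any claim that something is new, unique, unknown or untested is made for them only; others in the source may bear on it.

Measured in a physicochemical assay for lipophilicity, measured as octanol-water partition; on this read-out higher numbers stand for higher lipophilicity and lower numbers for lower lipophilicity:
- compound 1 `CC(C)=CCC/C(C)=C/CC/C(C)=C/Cn1cc(-c2ccccc2)nn1`: 6.95
- compound 2 `CC(C)=CCC/C(C)=C/CC/C(C)=C\Cn1cc(-c2ccccc2)nn1`: 6.95
- compound 3 `CC(C)=CCC/C(C)=C/Cn1cc(-c2ccccc2)nn1`: 4.91

Compound 1 stands level with compound 2 at the top of these numbers, well clear of compound 3. Compound 4 `CCCCCCCCc1cn(C/C=C(\C)CC/C=C(\C)CCC=C(C)C)nn1` carries octyl in place of phenyl on an aromatic carbon. For the measured compounds named here, no measured step touches that group. The step of no change at the digits printed from compound 1 to compound 2 (within the scatter) concerns configuration only and offers no guide to size. The step of a number 2.04 log units lower from compound 1 to compound 3 (beyond the scatter) is large, and there carbon leaves. Here carbon is gained, so on the strength of that step a smaller rise in this assay is expected. The estimate amounts to a number 1.45 log units higher from compound 1 to compound 4 (beyond the scatter). For compound 4 the expected value is 8.4, with an estimated range of 7.6 to 9.2.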

Compound 4, partition coefficient: 8.76
Beside the measured number, compound 4's estimate is 0.36 log units below it, within the range that was stated.
By their numbers in this assay, from the lowest: compound 3; then compounds 1 and 2 (each within the scatter of the next); then compound 4.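

Octyl in place of phenyl on an aromatic carbon gives a number 1.81 log units higher from compound 1 to compound 4 (beyond the scatter) in this assay, a large step. Compounds 1, 2 and 3 all keep phenyl at this position, so only now does the number prove responsive to the group here, and an open chain replacing the aromatic ring raises it. Nothing among the data shown accounts for the size of this rise.

The compounds shown do not separate the loss of the ring from the gain of the chain within this step. Hexyl or cyclohexyl at this position could address that split. Also open, from the compounds shown here alone, is how a longer chain, or an octyl chain ending in an amine or a carboxylic acid, would read here.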